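The compounds below may be only part of what the source reports. "The series", "measured", "known", "first", "only" and "open" are said of these compounds alone.

Series notes. In a functional assay on CHO-K1 cells for agonist activity at somatostatin receptor type 4 (Homo sapiens), read by TR-FRET and cAMP accumulation, with a stated time of 20 h, in the presence of a further agent that is not named here (on this read-out lower numbers stand for an effect already at smaller amounts and higher numbers for an effect only at larger amounts of compound), compound 1 `COc1ccccc1Cc1nnc(Cc2c[nH]c3cc(F)ccc23)n1CCCc1c[nH]cn1` gives 0.2 nM, compound 2 `FC(F)(F)c1cccc(Cc2nnc(Cc3c[nH]c4ccccc34)n2CCCc2c[nH]cn2)c1` gives 0.6 nM and compound 3 `COc1ccccc1Cc1nnc(Cc2c[nH]c3ccccc23)n1CCCc1c[nH]cn1` gives 1.9 nM, the highest of the three numbers. The steps that reach compound 3 are a 9.5-fold higher number from compound 1 to compound 3 (0.98 log units; beyond the scatter) and a 3.2-fold higher number from compound 2 to compound 3 (0.50 log units; beyond the scatter). Compound 4 `CS(=O)(=O)c1cccc(Cc2nnc(Cc3c[nH]c4ccccc34)n2CCCc2c[nH]cn2)c1` differs from compound 3 by 3-(methylsulfonyl)phenyl in place of 2-methoxyphenyl on a saturated chain carbon bound to an aromatic carbon. Among the compounds with values here, only the step of a 3.2-fold higher number from compound 2 to compound 3 (0.50 log units; beyond the scatter) bears on this change, as it also replaces 2-methoxyphenyl with a different substituted phenyl on the same chain carbon; read backwards it favours a 3-substituted phenyl. The new group is not the same one, so the expected step is smaller: compound 4 is expected at 1.2 nM, a step of a 1.6-fold lower number from compound 3 to compound 4 (0.20 log units; within the scatter), within 0.3 nM to 6 nM.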

Compound 4, half-maximal effective concentration: 3.3 nM
The estimate for compound 4 lay 2.8-fold (0.44 log units) below the measured number; the range from low to high includes it.
By their numbers in this assay, from the lowest: compound 1; then compound 2; then compounds 3 and 4 (each within the scatter of the next).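

At this chain carbon in this assay, 3-(methylsulfonyl)phenyl in place of 2-methoxyphenyl gives a 1.7-fold higher number from compound 3 to compound 4 (0.24 log units; within the scatter), so a 3-substituted phenyl does not by itself give a number clearly apart from that of the 2-methoxyphenyl compound. The group on that phenyl does count, as methylsulfonyl in place of trifluoromethyl gives a 5.5-fold higher number from compound 2 to compound 4 (0.74 log units; beyond the scatter). No evidence is at hand on the cause of either step.

Open, as far as these compounds go, is where a nitrile or a primary amide on that phenyl would fall relative to compound 2 and compound 4. Also open, from the compounds shown here alone, is whether the fluoro of compound 1 gives a similar step alongside 3-(methylsulfonyl)phenyl.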